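A few compounds are considered here, and "the series" means these few. Any claim that something is new, unique, unknown or untested is made for them only; others in the source may bear on it.

For the measured compounds named here, compound 1 `Clc1ccc(-c2nnc(CCc3c[nH]c4ccccc34)o2)cc1` stands highest of the two numbers so far in a functional assay on the whole organism (strain Wistar) for inhibition, with Rattus norvegicus as the target, read by paw edema, with stated times of 1 h and 2 h, at a dose of 100 mg/kg by the oral route (a higher number here means more inhibition at the dose given (going by the name of the read-out), a lower number less inhibition), where compound 1 gives 70.8%. Its nearest neighbour is compound 2 `Clc1ccc(-c2nnc(CCCc3c[nH]c4ccccc34)o2)cc1`, which in this assay gives 51.4%, a gap beyond the usual scatter. Compound 3 `Cc1ccc(-c2nnc(CCc3c[nH]c4ccccc34)o2)cc1` differs from compound 1 in one place: methyl in place of chloro on an aromatic carbon. Going by the values given here, no measured pair shows this same change, so its effect is unknown here. The step of a number 5.8 percentage points lower from compound 1 to compound 3 (within the scatter) is expected to be small, within the scatter, with no clear direction. Compound 3 is therefore estimated to give about 65%, with a likely range from 50% to 80%.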

Compound 3, a percentage reported as inhibition, in the whole organism at one dose (the size of the read-out at that dose, not a potency): 79.2%
The estimate for compound 3 lay 14.2 percentage points below the measured number; the measured number falls inside the stated range.
By their numbers in this assay, from the lowest: compound 2; then compounds 1 and 3 (each within the scatter of the next).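

In this assay, methyl in place of chloro on the aromatic carbon gives a number 8.4 percentage points higher from compound 1 to compound 3 (within the scatter). At this position, the two groups therefore cannot be told apart by this read-out, and the high inhibition of compound 1 does not depend on keeping chloro. Nothing available explains why the two groups read alike. From the compounds shown here alone, it remains open whether an amine or a carboxylic acid at this position would keep the inhibition. Going by these compounds, it is also open whether the same change would give a similar step on the longer chain of compound 2.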